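The compounds below may be only part of what the source reports. "The series", "measured", "known", "first", "only" and "open" are said of these compounds alone.

Working notes on the series. The compounds share the core of compound 1 `C/C(=N\O)C(=O)NCCCCCC(=O)Nc1ccccc1` and differ only in the group on a carbonyl carbon. In a functional assay on HCT-116 cells (Homo sapiens) for inhibition, read by colorimetric assay, with a stated time of 3 days (a higher number here means a weaker inhibitor, a lower number a stronger inhibitor), compound 1 gives only a limit, > 100000 nM. Compound 2 `NC(=O)C(=O)NCCCCCC(=O)Nc1ccccc1` in this assay likewise sits at a limit, > 100000 nM. Compound 3 `O=C(CCCCCNC(=O)c1ccc[nH]1)Nc1ccccc1` also returns only a limit in this assay, > 100000 nM. The steps a step that the two limits leave unreadable from compound 1 to compound 2, a step that the two limits leave unreadable from compound 1 to compound 3 and a step that the two limits leave unreadable from compound 2 to compound 3 are thus unreadable; the whole set rests at the limit of > 100000 nM in this assay, at which 3 of the 3 values shown sit. Compound 4 `CC(C)(C)C(O)(O)C(=O)NCCCCCC(=O)Nc1ccccc1` differs from compound 3 by 1,1-dihydroxy-2,2-dimethylpropyl in place of 1H-pyrrol-2-yl on a carbonyl carbon. For the measured compounds named here, no measured step gives a readable size or direction to build on, so the expected step from compound 3 to compound 4 is a number no higher from compound 3 to compound 4 (the limit leaves the size open), most likely ending again at a limit. Compound 4 is estimated at 100000 nM, within 30000 nM to 300000 nM.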

Compound 4, half-maximal inhibitory concentration: 54400 nM
For compound 4 the middle estimate is 1.8-fold (0.26 log units) above the measured one, within the range that was stated.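

At this carbonyl carbon, 1,1-dihydroxy-2,2-dimethylpropyl is the one group shown that gives a readable value in this assay, while the others remain at a limit: the limit of > 100000 nM in this assay, at which 3 of the 4 values shown sit. The change gives an at least 1.8-fold lower number from compound 3 to compound 4 (0.26 log units; that floor lies within the scatter), an at least 1.8-fold lower number from compound 2 to compound 4 (0.26 log units; that floor lies within the scatter) and an at least 1.8-fold lower number from compound 1 to compound 4 (0.26 log units; that floor lies within the scatter). Going by these compounds, each of these steps starts from a limit, so its true size stays open, and the printed floors alone do not separate compound 4 from the other compounds beyond the scatter.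

On these data alone, whether a plain tert-butyl or a carboxylic acid on this carbonyl carbon would also give a readable value remains open. So does the effect of a longer chain in the shared core.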